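Cutting the Tether Between Core and Iodomethyl Carbonyl Group

The compounds below may be only part of what the source reports. "The series", "measured", "known", "first", "only" and "open" are said of these compounds alone.

Compound 1 `Nc1ncnc2c1nc(NCCCCCCCCNC(=O)CI)n2[C@@H]1O[C@H](COP(=O)(O)OP(=O)(O)OP(=O)(O)O)[C@@H](O)[C@H]1O` and compound 2 `Nc1ncnc2c1nc(NCCCCNC(=O)CI)n2[C@@H]1O[C@H](COP(=O)(O)OP(=O)(O)OP(=O)(O)O)[C@@H](O)[C@H]1O` share one core, while compound 3 `O=C(CI)NCCCCCCC(=O)NCCCCCCNc1ncnc2c1ncn2[C@@H]1O[C@H](COP(=O)(O)OP(=O)(O)OP(=O)(O)O)[C@@H](O)[C@H]1O` and compound 4 `O=C(CI)NCCC(=O)NCCCCCCNc1ncnc2c1ncn2[C@@H]1O[C@H](COP(=O)(O)OP(=O)(O)OP(=O)(O)O)[C@@H](O)[C@H]1O` share another; the difference between the two cores is not broken down here. In an assay on isolated protein for inhibition of hexokinase-3 (Rattus norvegicus), with a stated time of 6 h, tested at 10 mM (a higher number here means more inhibition at the concentration tested (going by the name of the read-out), a lower number less inhibition), compound 1 gives 0%, compound 2 gives 0% and compound 3 gives 0%, so compound 3 stands level with both of the first two. The step of no change at the digits printed from compound 1 to compound 2 (within the scatter) corresponds to the change (((iodomethyl)carbonyl)amino in place of 4-(((iodomethyl)carbonyl)amino)butyl on a saturated chain carbon, four bonds along the chain from a nitrogen on an aromatic ring). Compound 4 is reached from compound 3 by the same kind of change, (((iodomethyl)carbonyl)amino in place of 4-(((iodomethyl)carbonyl)amino)butyl on a saturated chain carbon, two bonds along the chain from a carbonyl carbon); what differs around the place is that in compound 1 the group sits on a saturated chain carbon, four bonds along the chain from a nitrogen on an aromatic ring, whereas in compound 3 it sits on a saturated chain carbon, two bonds along the chain from a carbonyl carbon. Because no change at the digits printed from compound 1 to compound 2 (within the scatter) shows no change and compound 3 already sits at 0%, compound 4 is expected to give 0% in this assay, an estimated step of no change at the digits printed from compound 3 to compound 4 (within the scatter), with the expected range running from 0% to 8%.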

Compound 4, a percentage reported as inhibition, at one concentration (the size of the read-out at that concentration, not a potency): 0%
For compound 4 middle estimate and measured number coincide at the digits printed; measured number inside the range.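

In this assay, putting ((iodomethyl)carbonyl)amino in place of 4-(((iodomethyl)carbonyl)amino)butyl gives no change at the digits printed from compound 3 to compound 4 (within the scatter). Within the data shown here, the change therefore reads alike on both cores: the same change on two cores in this assay, no change at the digits printed (within the scatter) from compound 1 to compound 2 and no change at the digits printed (within the scatter) from compound 3 to compound 4, 0 percentage points apart, within the scatter of two such steps This agreement carries little weight, however: all four compounds share one reading, with compound 4 at 0%, so the steps show only that this change does not move either core away from that reading, and they do not show how it would act on a compound with measurable inhibition.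

The compounds shown leave open whether a longer chain, or an amine or a chloromethyl carbonyl group in place of the iodomethyl carbonyl end, would give any inhibition in this assay. Among these compounds, they also leave open what the difference between the two cores contributes, as no single step here separates it from the rest of the structure.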